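Compound 3 to compound 4: a new side chain

The source may hold more compounds than are shown below. What is called first, only, known or untested is meant among the compounds shown, and "the series" means these compounds.

Values in a functional assay on MCF7 cells (Homo sapiens) for inhibition, read by fluorescence, with a stated time of 72 h (a higher number here means a weaker inhibitor, a lower number a stronger inhibitor), are as follows:

- Compound 1 `Cn1cnc2c(NC(=N)N)nc(N)nc21`: > 100000 nM (a limit)
- Compound 2 `CCn1cnc2c(N)nc(N)nc21`: > 100000 nM (a limit)
- Compound 3 `CC(C)n1cnc2c(NC(=N)N)nc(NCCO)nc21`: 12400 nM

Of these three, compound 3 alone has a numerical value, 12400 nM. The values of compound 1 and compound 2 are limits. Compound 4 `CC[C@@H](N)COc1nc(NC(=N)N)c2ncn(C(C)C)c2n1` carries 2-aminobutoxy in place of (2-hydroxyethyl)amino on an aromatic carbon and has not yet been measured. Among the measured compounds shown here, no measured step between these compounds shows the size of such a change, so only a small shift towards stronger inhibition in this assay is expected, no larger than the usual scatter. The estimated move is a 1.8-fold lower number from compound 3 to compound 4 (0.25 log units; within the scatter). For compound 4, the estimated value is 7000 nM, with an expected range from 2000 nM to 30000 nM.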

Compound 4, half-maximal inhibitory concentration: > 100000 nM
Compound 4: only a limit was reported; the forecaster's own chance of this, stated with the estimate: 12%; middle value at least 14-fold (1.15 log units) away from the limit.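

With 2-aminobutoxy in place of (2-hydroxyethyl)amino, this assay shows an at least 8.0-fold higher number from compound 3 to compound 4 (0.90 log units; beyond the scatter) and thus gives the first sign that the side chain at this carbon between two ring nitrogen atoms can change the read-out beyond the scatter. The value of compound 4 is a limit, so this step gives only the smallest possible size of the change: the limit of > 100000 nM in this assay, at which 3 of the 4 values shown sit.

Whether the oxygen link or the longer chain accounts for the loss stays open. So does the outcome for a 2-aminobutylamino or a 2-hydroxyethoxy group at this carbon.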